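The source may report more compounds than this note shows. Statements on the series, on what has been measured and on what is new or still open speak of the compounds shown alone.

Measured in a functional assay on MCF7 cells (Homo sapiens) for cytotoxicity, read by MTT assay, with a stated time of 48 h; on this read-out higher numbers stand for weaker inhibition and lower numbers for stronger inhibition:
Compound 1 `CCc1ccc(NC(=S)N/N=C\c2ccnc3ccccc23)cc1`: 820 nM
Compound 2 `S=C(N/N=C\c1ccnc2ccccc12)Nc1ccccc1`: 1070 nM

Within the data shown here, only two numbers exist so far. Compound 2, at 1070 nM, cannot be told apart from compound 1, since the two values lie within the usual scatter of repeated measurements.

Compound 3 `S=C(N/N=C\c1ccnc2ccccc12)Nc1ccc(Cl)cc1` keeps the whole of compound 2 except for one substituent: chloro in place of hydrogen on an aromatic carbon. A chloro takes the place of a hydrogen on an aromatic carbon, para to a large group, so phenyl becomes 4-chlorophenyl.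

Among the measured compounds shown here, one measured step bears on this change. It also swaps a single substituent for hydrogen on an aromatic carbon, there an ethyl: a 1.3-fold higher number from compound 1 to compound 2 (0.12 log units; within the scatter). That step stays within the scatter. For the measured compounds named here, it is only one step, and ethyl is not chloro, so the evidence is thin. Even so, no step beyond the scatter is expected in this assay, in either direction. The expected change is a 1.2-fold lower number from compound 2 to compound 3 (0.08 log units; within the scatter). Compound 3 is estimated at 900 nM, with an expected range from 350 nM to 2300 nM.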

Compound 3, half-maximal inhibitory concentration: 1070 nM
For compound 3 the middle estimate is 1.2-fold (0.08 log units) below the measured one, and the stated range covers the measured number.
By their numbers in this assay, from the lowest: compounds 1, 2 and 3 (each within the scatter of the next).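

In this assay this position now carries three different substituents, and the new result adds a halogen to the earlier comparison of hydrogen and ethyl. Placing chloro on the aromatic carbon para to a large group gives no change at the digits printed from compound 2 to compound 3 (within the scatter), and replacing ethyl with chloro gives a 1.3-fold higher number from compound 1 to compound 3 (0.12 log units; within the scatter), so neither step involving chloro moves the number beyond the usual scatter. No supporting measurement is available to explain why these three compounds cannot be told apart.

On these data alone, three substituents are a small sample, so it remains open whether the number would also hold with an amine, a carboxylic acid or a longer chain such as butyl at this position. As far as these compounds go, it is equally open whether a change to the shared core, rather than to this substituent, would produce a step beyond the scatter.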